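The source may report more compounds than this note shows. Statements on the series, on what has been measured and on what is new or still open speak of the compounds shown alone.

Measured compounds:
compound 1 `COC(=O)CCNC(=O)[C@@H]1O[P@@](=O)(OCOC(=O)c2ocnc2C)OCC1(C)C` – 0.52 h
compound 2 `COC(=O)CCNC(=O)[C@@H]1O[P@](=O)(Oc2ccc(C(F)(F)F)cc2)OCC1(C)C` – > 1 h

In an ADME assay on blood (Homo sapiens) for pharmacokinetics (a higher number here means that the compound lasts longer, a lower number that the compound disappears faster), compound 1 gives 0.52 h. For compound 2 the result in this assay is a limit of the assay, > 1 h, and not a number. Among the compounds with values here, compound 1 therefore holds the only number among the values shown; the other value sits at the limit of > 1 h in this assay, at which 1 of the 2 values shown sits. Within the data shown here, no step between measured compounds that differ in one place is available, so nothing measured tells how a single change moves the half-life here.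

Compound 3 `COC(=O)CCNC(=O)[C@@H]1O[P@@](=O)(OCOC(=O)c2scnc2C)OCC1(C)C` has not yet been measured in this assay. Compared with compound 1 it differs in one place: 4-methyl-1,3-thiazol-5-yl in place of 4-methyl-1,3-oxazol-5-yl on a carbonyl carbon. This exchange at the carbonyl carbon is expected to move the half-life little, if at all, so the step of a 1.2-fold higher number from compound 1 to compound 3 (0.06 log units; within the scatter) is estimated to fall within the usual scatter of repeated measurements. Compound 3 is expected to give about 0.6 h in this assay, with a likely range from 0.3 h to 1.2 h.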

Compound 3, half-life: > 1 h
Compound 3: only a limit was reported; the forecaster's own chance of this, stated with the estimate: 15%; middle value at least 1.6-fold (0.22 log units) from the limit.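

In this assay, within the data shown here, the exchange of 4-methyl-1,3-oxazol-5-yl for 4-methyl-1,3-thiazol-5-yl on a carbonyl carbon provides the first step between two compounds that differ in one place: an at least 1.9-fold higher number from compound 1 to compound 3 (0.28 log units; that floor lies within the scatter). Compound 3 gives > 1 h, which is a limit of the assay and not a number, so the step gives only a floor, and that floor alone does not establish a real gain over the usual scatter. Even so, this single exchange takes the series from the only number shown to the limit: the limit of > 1 h in this assay, at which 2 of the 3 values shown sit.

From the compounds shown here alone, how far compound 3 lies beyond its limit stays unknown, and so does the true size of the step from the oxazole to the thiazole group. Going by these compounds, it also remains open whether an unsubstituted 1,3-thiazol-5-yl, a phenyl or a pyridin-3-yl on the same carbonyl carbon would stay at this limit or return to the range of compound 1, and so whether the result depends on the sulfur, on the methyl group or on the ring as a whole.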